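Hydroxyphenyl-substituted pyridines against topoisomerase 1

A few compounds are considered here, and "the series" means these few. Any claim that something is new, unique, unknown or untested is made for them only; others in the source may bear on it.

Measured so far:
compound 1 `Oc1ccccc1-c1cc(-c2ccccc2O)nc(-c2ccccc2O)c1`: 0%
compound 2 `Oc1ccc(-c2cc(-c3cccc(O)c3)cc(-c3ccc(O)cc3)n2)cc1`: 0%
compound 3 `Oc1ccc(-c2cc(-c3cccc(O)c3)cc(-c3ccccc3O)n2)cc1`: 8.4%

In an assay on isolated protein for inhibition of DNA topoisomerase 1 (Homo sapiens), with a stated time of 30 min, tested at 100 uM (on this read-out lower numbers stand for less inhibition and higher numbers for more inhibition at the one concentration tested (going by the name of the read-out)), compound 1 gives 0% and compound 2 gives 0%; the two are level at the digits printed and within the scatter of each other. Compound 3 gives 8.4% in this assay, also within the scatter of both others.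

Among the compounds with values here, the one measured step, a number 8.4 percentage points lower from compound 3 to compound 2 (within the scatter), is the change (4-hydroxyphenyl in place of 2-hydroxyphenyl on an aromatic carbon). The same kind of change is now made from compound 1 to compound 4 `Oc1ccc(-c2cc(-c3ccccc3O)nc(-c3ccccc3O)c2)cc1`, as 4-hydroxyphenyl in place of 2-hydroxyphenyl on an aromatic carbon. The surroundings differ: in compound 3 the exchanged group sits next to the ring nitrogen, meta to a 3-hydroxyphenyl group and meta to a 4-hydroxyphenyl group, whereas in compound 1 it sits opposite the ring nitrogen, meta to two 2-hydroxyphenyl groups. The difference between the cores of compound 1 and compound 3 is not broken down here.

The expected step in this assay is a number 1 percentage points higher from compound 1 to compound 4 (within the scatter), put beside the measured one because the earlier step of a number 8.4 percentage points lower from compound 3 to compound 2 (within the scatter) stayed within the scatter and compound 1 starts from 0%. Compound 4 is therefore estimated at 1%, between -8% and 10%.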

Compound 4, a percentage reported as inhibition, at one concentration (the size of the read-out at that concentration, not a potency): 3.7%
Beside the measured number, compound 4's estimate is 2.7 percentage points below it, and the stated range covers the measured number.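

In this assay the exchange of 2-hydroxyphenyl for 4-hydroxyphenyl opposite the ring nitrogen is a number 3.7 percentage points higher from compound 1 to compound 4 (within the scatter) on the core of compound 1. Set beside the earlier case, the two steps do not separate: the same change on two cores in this assay, a number 8.4 percentage points lower (within the scatter) from compound 3 to compound 2 and a number 3.7 percentage points higher (within the scatter) from compound 1 to compound 4, 12.1 percentage points apart, within the scatter of two such steps. This gives no sign that the change reads differently on the two cores, but with each step within the scatter, neither has a direction that can be read, so it does not show that the change carries from one core to the other with a common size or sign.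

The compounds shown leave open whether a group other than a hydroxyphenyl, such as an aminophenyl, a carboxylic acid or a longer chain, would bring inhibition clear of the scatter on this core. Going by these compounds, it also remains open whether the position of the hydroxyl matters at all in a compound with a readable level of inhibition.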